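The source may hold more compounds than are shown below. What is called first, only, known or untested is meant among the compounds shown, and "the series" means these compounds.

Measured so far in an assay on cells for antagonist activity at transient receptor potential cation channel subfamily V member 1 (Homo sapiens), read by FLIPR and calcium flux, with a stated time of 6 min; a lower number here means a stronger inhibitor, a higher number a weaker inhibitor:
- compound 1 `CC(C(=O)NCc1ccc(C(C)(C)C)nc1N1CCCC1)c1ccc(NS(C)(=O)=O)c(F)c1`: 1.2 nM
- compound 2 `CCC1CCN(c2nc(C(C)(C)C)ccc2CNC(=O)C(C)c2ccc(NS(C)(=O)=O)c(F)c2)CC1`: 0.1 nM
- compound 3 `CCOCCOc1nc(C(C)(C)C)ccc1CNC(=O)C(C)c1ccc(NS(C)(=O)=O)c(F)c1`: 23.9 nM

Compound 2 stands lowest of the three numbers in this assay. Its nearest neighbour is compound 1, the step being a 12-fold lower number from compound 1 to compound 2 (1.08 log units; beyond the scatter); the furthest is compound 3, with a 240-fold higher number from compound 2 to compound 3 (2.38 log units; beyond the scatter). Compound 1 and compound 3 are separated by a 20-fold higher number from compound 1 to compound 3 (1.30 log units; beyond the scatter).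

Compound 4 `CC(C(=O)NCc1ccc(C(C)(C)C)nc1OCc1ccccc1)c1ccc(NS(C)(=O)=O)c(F)c1` is not yet measured. (benzyloxy in place of 4-ethylpiperidin-1-yl on an aromatic carbon). Going by the values given here, two measured steps bear on this change. The most direct is a 240-fold higher number from compound 2 to compound 3 (2.38 log units; beyond the scatter), where the same 4-ethylpiperidin-1-yl was exchanged for 2-ethoxyethoxy, also an oxygen-attached group; the other is a 20-fold higher number from compound 1 to compound 3 (1.30 log units; beyond the scatter), which shows the move from a ring amine to 2-ethoxyethoxy costing heavily as well. Benzyloxy differs from 2-ethoxyethoxy in carrying a six-membered aromatic ring of carbon only rather than a chain, so the full penalty seen in compound 3 need not recur, but a rise in the number beyond the scatter is expected.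

Compound 4 is therefore estimated at 4 nM, with a range of 0.6 nM to 25 nM. This corresponds to an expected step of a 40-fold higher number from compound 2 to compound 4 (1.60 log units; beyond the scatter) in this assay.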

Compound 4, inhibition constant: 4.4 nM
For compound 4 the middle estimate is 1.1-fold (0.04 log units) below the measured one, within the range that was stated.
By their numbers in this assay, from the lowest: compound 2; then compound 1; then compound 4; then compound 3.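

In this assay, both oxygen-attached groups at this place, next to the ring nitrogen, now give higher numbers than both ring amines, and none of the four compounds goes against this: benzyloxy gives a 44-fold higher number from compound 2 to compound 4 (1.64 log units; beyond the scatter) and a 3.7-fold higher number from compound 1 to compound 4 (0.56 log units; beyond the scatter). The oxygen link does not fix the size of the loss, however, as the phenyl of benzyloxy in place of the ethoxymethyl of 2-ethoxyethoxy gives a 5.4-fold lower number from compound 3 to compound 4 (0.73 log units; beyond the scatter), so the group beyond the oxygen also changes the number. No measurement at hand accounts for any of these differences.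

Benzyloxy and 4-ethylpiperidin-1-yl differ both in the atom attached to the core and in the ring they carry, so the step from the amine to the ether does not show how much of the change belongs to each. Benzylamino, with nitrogen in place of the benzyloxy oxygen, would test the attached atom while keeping the phenyl ring, and 4-ethylcyclohexyloxy would test the oxygen link while keeping a saturated six-membered ring.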